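Bromo for Ethynyl on Two Fused Cores

A few compounds are considered here, and "the series" means these few. Any claim that something is new, unique, unknown or untested is made for them only; others in the source may bear on it.

Four small fused bicyclic compounds are compared here, each tested in a functional assay on HCT-116 cells (Homo sapiens) for cytotoxicity, with a stated time of 3 days; on this read-out higher numbers stand for weaker inhibition and lower numbers for stronger inhibition. Compound 1 `C#Cc1nc2ccccc2[se]1` gives 25000 nM. Compound 2 `Brc1nc2ccccc2[se]1` reaches only the limit of the assay, > 40000 nM, which is a limit and not a number. The change from compound 1 to compound 2 is bromo in place of ethynyl on an aromatic carbon, and it made an at least 1.6-fold higher number from compound 1 to compound 2 (0.20 log units; that floor lies within the scatter); the value that sets that floor is the limit of > 40000 nM in this assay, at which 1 of the 3 values shown sits.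

Compound 3 `C#Cc1nc2ccccc2n1C` is built on a different core, and in this assay compound 3 gives 19400 nM. The values of compound 1 and compound 3 lie within the usual scatter of each other. The difference between the two cores is not broken down here.

Compound 4 `Cn1c(Br)nc2ccccc21` has not yet been measured. It differs from compound 3 by bromo in place of ethynyl on an aromatic carbon. Going by the values given here, this is the same kind of change as the one from compound 1 to compound 2, but its surroundings differ: in the earlier pair the carbon sits in a five-membered aromatic ring with 1 nitrogen and 1 selenium, next to the ring nitrogen and next to the ring selenium, whereas here it sits in a five-membered aromatic ring with 2 nitrogen, between two ring nitrogen atoms, next to the ring atom that bears a methyl group.

Resting on the step of an at least 1.6-fold higher number from compound 1 to compound 2 (0.20 log units; that floor lies within the scatter), the expected step from compound 3 to compound 4 is a 2.1-fold higher number from compound 3 to compound 4 (0.31 log units; beyond the scatter). Compound 4 is therefore estimated at 40000 nM, expected to fall somewhere from 15000 nM to 100000 nM, with a real chance that only a limit is reported.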

Compound 4, half-maximal inhibitory concentration: > 40000 nM
Compound 4: a limit, no number; the forecaster's own chance of this, stated with the estimate: 50%; the middle value lies on the limit itself.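

Putting bromo in place of ethynyl on the second core gives an at least 2.0-fold higher number from compound 3 to compound 4 (0.31 log units; beyond the scatter) in this assay, so this step, unlike the floor of the earlier one, clears the usual scatter. The change carries over in one plain sense, since on both cores the bromo compound ends at a limit and not at a number: the limit of > 40000 nM in this assay, at which 2 of the 4 values shown sit. What this does not show is whether the change has the same size on the two cores, since both steps are only floors: the same change on two cores in this assay, an at least 1.6-fold higher number (0.20 log units; that floor lies within the scatter) from compound 1 to compound 2 and an at least 2.0-fold higher number (0.31 log units; beyond the scatter) from compound 3 to compound 4; the limit leaves it open whether they differ.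

The compounds shown compare only ethynyl and bromo at this one carbon, so it stays open whether another group there, such as an amine, a carboxylic acid or a longer chain, would give a reading clear of the limit and stronger than those of the ethynyl compounds. On these data alone, it also stays open whether a group placed elsewhere on either core would change how much the swap from ethynyl to bromo matters, and whether the two cores would then behave alike.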